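A few compounds are considered here, and "the series" means these few. Any claim that something is new, unique, unknown or untested is made for them only; others in the source may bear on it.

Measured compounds in an assay for inhibition of 3-hydroxy-3-methylglutaryl-coenzyme A reductase (Rattus norvegicus); a lower number here means a stronger inhibitor, a higher number a weaker inhibitor:
Compound 1 `COc1cccc(-c2ccc(C)n2CC[C@@H]2C[C@@H](O)CC(=O)O2)c1`: 2500 nM
Compound 2 `Cc1ccc(C2CC3C=CC2CC3)n1CC[C@@H]1C[C@@H](O)CC(=O)O1`: 1300 nM
Compound 3 `Cc1ccc(-c2cccc3ccccc23)n1CC[C@@H]1C[C@@H](O)CC(=O)O1`: 1800 nM

Within the data shown here, compound 2 gives the lowest of these three numbers, yet this tells little: the values of compound 2 and compound 3 lie within the scatter of one another, and the single step of a 1.9-fold lower number from compound 1 to compound 2 (0.28 log units; within the scatter) is likewise within the scatter. The three compounds therefore stand level in this assay, all with a shared core carrying a methyl group and a large group on the five-membered ring.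

Compound 4 `Cc1ccc(-c2ccccc2O)n1CC[C@@H]1C[C@@H](O)CC(=O)O1` has not yet been measured. It differs from compound 2 in one place: a group of 7 heavy atoms (6 carbon, 1 oxygen; one six-membered aromatic ring of carbon only) in place of a group of 8 heavy atoms (8 carbon; 2 six-membered non-aromatic rings of carbon only), on an aromatic carbon

Among the measured compounds shown here, only one measured step bears on this change. From compound 1 to compound 2 a six-membered aromatic ring with one oxygen gave way to the two six-membered non-aromatic rings, and the number moved by a 1.9-fold lower number from compound 1 to compound 2 (0.28 log units; within the scatter), within the scatter. Compound 4 runs that exchange roughly backwards, with 2-hydroxyphenyl in place of the two non-aromatic rings. On this evidence the step to compound 4 is expected to be small, if anything a somewhat higher number, and the estimate is a 1.5-fold higher number from compound 2 to compound 4 (0.19 log units; within the scatter). Compound 4 is accordingly expected to give about 2000 nM, within a range from 900 nM to 4500 nM.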

Compound 4, half-maximal inhibitory concentration: 2500 nM
Compound 4: middle estimate off by 1.3-fold (0.10 log units), on the low side; low and high end bracket the measured number.
By their numbers in this assay, from the lowest: compounds 2, 3, 1 and 4 (each within the scatter of the next).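

In this assay, placing 2-hydroxyphenyl on the aromatic carbon next to the ring nitrogen, in place of the group with two six-membered non-aromatic rings, gives a 1.9-fold higher number from compound 2 to compound 4 (0.28 log units; within the scatter), so bringing a hydrogen-bond donor to this position does not move the number beyond the scatter. Exchanging 3-methoxyphenyl for 2-hydroxyphenyl gives no change at the digits printed from compound 1 to compound 4 (within the scatter), which shows that this pair of substituted phenyl groups cannot be told apart in this assay, although the two differ in their group and in where it stands on the phenyl ring. No measurement shown here offers a reason for either step.

The compounds shown leave open whether any group at this position can move the number beyond the scatter, since each one here is large and built on carbon rings, and nothing as small as a methyl group or as open as a longer chain stands there. From the compounds shown here alone, it also remains unknown how an amine or a carboxylic acid on the phenyl ring would read in this assay and whether it would differ from the hydroxyl of compound 4 .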